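The compounds below may be only part of what the source reports. "The series", "measured", "known", "first", "only" and "open" are said of these compounds alone.

Working notes on the series, all read in a functional assay on V79 cells (Cricetulus griseus) for cytotoxicity, read by colony formation; on this read-out higher numbers stand for weaker inhibition and lower numbers for stronger inhibition. Compound 1 `NCC1CCN(c2c(F)cc3c(=O)c(C(=O)O)cn(C4CC4)c3c2Cl)C1` gives 8 ug/mL, compound 2 `CC1(CN)CCN(c2c(F)cc3c(=O)c(C(=O)O)cn(C4CC4)c3c2F)C1` gives 8 ug/mL, and compound 3 `CC1(CN)CCN(c2c(F)cc3c(=O)c(C(=O)O)cn(C4CC4)c3c2Cl)C1` gives 8 ug/mL, so compound 3 stands level with both of the others.

The next structure is compound 4 `CNCC1(C)CCN(c2c(F)cc3c(=O)c(C(=O)O)cn(C4CC4)c3c2Cl)C1`. It carries methyl in place of hydrogen on an amine nitrogen, which turns the aminomethyl into (methylamino)methyl.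

Within the data shown here, no measured step makes this exact change. The closest is no change at the digits printed from compound 1 to compound 3 (within the scatter), which also puts methyl in place of hydrogen, but on a saturated ring carbon. The other measured step, no change at the digits printed from compound 2 to compound 3 (within the scatter), is chloro in place of fluoro on an aromatic carbon and bears on the question only as a sign of how flat the set is so far. Neither step leaves the scatter. Among the measured compounds shown here, the set holds no example of a change on the amine nitrogen, so this support is indirect and the range should stay generous.

On this evidence, no step beyond the scatter is expected, and no direction can be assigned. The expected step is no change at the digits printed from compound 3 to compound 4 (within the scatter). The estimate for compound 4 is 8 ug/mL, with an expected range of 4 ug/mL to 20 ug/mL.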

Compound 4, half-maximal inhibitory concentration: 23 ug/mL
The estimate for compound 4 lay 2.9-fold (0.46 log units) below the measured number, outside the stated range (above it).
By their numbers in this assay, from the lowest: compounds 1, 2 and 3 (each within the scatter of the next); then compound 4.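

In this assay, among these compounds, the amine nitrogen is the first place in the set where a change moves the number beyond the scatter: methyl in place of hydrogen there gives a clear rise (a 2.9-fold higher number from compound 3 to compound 4 (0.46 log units; beyond the scatter)), while methyl in place of hydrogen on a saturated ring carbon left the number flat (no change at the digits printed from compound 1 to compound 3 (within the scatter)). Replacing 3-(aminomethyl)pyrrolidin-1-yl with 3-methyl-3-((methylamino)methyl)pyrrolidin-1-yl, which carries both methyls, gives a step of the same printed size (a 2.9-fold higher number from compound 1 to compound 4 (0.46 log units; beyond the scatter)), so a methyl does not act alike in these two places on this read-out. Nothing among the data accounts for the rise seen with the methyl on the amine nitrogen.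

Still open, from the compounds shown here alone, is whether the number keeps rising with more substitution on this nitrogen, as a dimethylamino or ethylamino group in place of the methylamino group would show. Also open, going by these compounds, is whether the step holds on the other backgrounds in the set, that is, with (methylamino)methyl on a ring lacking the ring methyl, or with fluoro in place of chloro on the aromatic carbon.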